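The source may hold more compounds than are shown below. What is called first, only, known or untested is meant among the compounds shown, and "the series" means these compounds.

Measured compounds in a functional assay on the whole organism (strain albino) for inhibition, with Rattus norvegicus as the target, read by paw edema, with stated times of 30 min and 2 h, at a dose of 0.28 mmol/kg by the oral route; on this read-out lower numbers stand for less inhibition and higher numbers for more inhibition at the one dose given (going by the name of the read-out): compound 1 `C/C(=N\O)c1ccc(NC(=O)CSc2nnc(-c3ccccc3)n2-c2ccccc2)cc1` gives 52%; compound 2 `CCn1c(SCC(=O)Nc2ccc(/C(C)=N/O)cc2)nnc1-c1ccc(OC)c(OC)c1` gives 65%; compound 3 `COc1ccc(-c2nnc(SCC(=O)Nc3ccc(/C(C)=N/O)cc3)n2-c2ccccc2)cc1` gives 56%.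

Among the three numbers compound 3 stands second highest, with compound 1 nearest and compound 2 furthest, both gaps within the scatter. Compound 4 `CCn1c(SCC(=O)Nc2ccc(/C(C)=N/O)cc2)nnc1-c1ccc(OC)cc1` differs from compound 3 by ethyl in place of phenyl on an aromatic nitrogen. No measured step tests this change directly; the one step shown, a number 4 percentage points higher from compound 1 to compound 3 (within the scatter), concerns a different place. Compound 2, which carries the ethyl group but also a second methoxy group, and compound 3 show values within the scatter of each other. The step of a number 4 percentage points higher from compound 3 to compound 4 (within the scatter) is therefore expected to stay within the scatter. For compound 4 the estimate is 60%, in the range 50% to 70%.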

Compound 4, a percentage reported as inhibition, in the whole organism at one dose (the size of the read-out at that dose, not a potency): 58%
For compound 4 the middle estimate is 2 percentage points above the measured one; low and high end bracket the measured number.
By their numbers in this assay, from the lowest: compounds 1, 3, 4 and 2 (each within the scatter of the next, the first and the last beyond it).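

In this assay, the position on the aromatic nitrogen now has a direct test: ethyl in place of phenyl gives a number 2 percentage points higher from compound 3 to compound 4 (within the scatter), so the read-out does not separate these two groups here. Hydrogen in place of methoxy on an aromatic carbon gives a number 7 percentage points lower from compound 2 to compound 4 (within the scatter), a second reading of that change. The two readings agree across the two cores: the same change on two cores in this assay, a number 4 percentage points higher (within the scatter) from compound 1 to compound 3 and a number 7 percentage points higher (within the scatter) from compound 4 to compound 2, 3 percentage points apart, within the scatter of two such steps

The compounds shown leave open whether an amine, a carboxylic acid or a chain longer than ethyl on this aromatic nitrogen would move the read-out beyond the scatter. With only phenyl and ethyl at this position, no trend can be read.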